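The compounds below may be only part of what the source reports. "The series", "measured", "known", "first", "only" and "open" are said of these compounds alone.

Measured so far in an assay for inhibition of Amine oxidase [flavin-containing] B (Homo sapiens), read by fluorescence, using microsomes, with a stated time of 30 min; on this read-out higher numbers stand for weaker inhibition and lower numbers for stronger inhibition:

Compound 1 `Cc1c(C)c2ccc(OCC3CCN(Cc4ccc(CO)cc4)CC3)cc2oc1=O`: 29 nM
Compound 2 `Cc1c(C)c2ccc(OCC3CCN(Cc4cccc(CO)c4)CC3)cc2oc1=O`: 76 nM
Compound 3 `Cc1c(C)c2ccc(OCC3CCN(CCCO[N+](=O)[O-])CC3)cc2oc1=O`: 250 nM

Compound 2 holds the second highest of these three numbers: in this assay it sits a 2.6-fold higher number from compound 1 to compound 2 (0.42 log units; beyond the scatter) and a 3.3-fold higher number from compound 2 to compound 3 (0.52 log units; beyond the scatter). Compound 4 `Cc1c(C)c2ccc(OCC3CCN(Cc4cccc(OCCCO[N+](=O)[O-])c4)CC3)cc2oc1=O` is not yet measured. It differs from compound 2 in one place: 3-(nitrooxy)propoxy in place of hydroxymethyl on an aromatic carbon. The closest guides are the steps around compound 2 itself, a 2.6-fold higher number from compound 1 to compound 2 (0.42 log units; beyond the scatter) and a 3.3-fold higher number from compound 2 to compound 3 (0.52 log units; beyond the scatter), both modest; compound 3, which also carries a nitrooxy chain, shows the highest number seen. Because compound 3 gives 250 nM, a modest rise in this assay is expected for compound 4, a 1.6-fold higher number from compound 2 to compound 4 (0.20 log units; within the scatter). Compound 4 is therefore estimated at 120 nM in this assay, within a range of 50 nM to 300 nM.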

Compound 4, half-maximal inhibitory concentration: 550 nM
For compound 4 the middle estimate is 4.6-fold (0.66 log units) below the measured one; the whole stated range lies below it.
By their numbers in this assay, from the lowest: compound 1; then compound 2; then compound 3; then compound 4.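

In this assay, putting 3-(nitrooxy)propoxy in place of hydroxymethyl on this aromatic carbon clearly weakens inhibition (a 7.2-fold higher number from compound 2 to compound 4 (0.86 log units; beyond the scatter)), so this position does not take the larger chain without loss. The change adds heavy atoms and removes the hydrogen-bond donor at once, and these compounds cannot separate those two differences. Nothing measured here explains the loss. As far as these compounds go, it remains open whether the chain or its nitrooxy end matters more. A plain propoxy group or a shorter 2-(nitrooxy)ethoxy group at this position would help to tell them apart.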